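A few compounds are considered here, and "the series" means these few. Any claim that something is new, unique, unknown or untested is made for them only; others in the source may bear on it.

In a functional assay on COLO 205 cells (Homo sapiens) for antiproliferative activity, with a stated time of 72 h (on this read-out lower numbers stand for stronger inhibition and higher numbers for weaker inhibition), compound 1 `C=C[C@@H]1C[C@@H](Cc2ccc(OC)c(O)c2)[C@H]2C(=O)C=CC(=C)[C@H]21` gives 92.8 nM. Compound 2 `C=C1C=CC(=O)[C@@H]2[C@H](Cc3ccc(OCOC)c(F)c3)CC[C@H]12` gives 75.7 nM, within the scatter of compound 1. Compound 3 `C=C1C=CC(=O)[C@@H]2[C@H](Cc3ccc(F)c(F)c3)CC[C@H]12` gives 428 nM, a number clearly higher than that of compound 1. Compound 1 therefore shares the lower part of this small range with compound 2.

Compound 4 `C=C1C=CC(=O)[C@@H]2[C@H](Cc3ccc(OC)c(O)c3)CC[C@H]12` has not yet been measured. It keeps the substituted aromatic ring of compound 1 and differs at one place: hydrogen in place of vinyl on a saturated ring carbon.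

Among the compounds with values here, no measured step makes this exact change. Within the data shown here, the only step available, a 5.7-fold higher number from compound 2 to compound 3 (0.75 log units; beyond the scatter), is modest and involves fluoro in place of methoxymethoxy on an aromatic carbon, so it bears only indirectly. It shows that the aromatic substituents can shift the number, and compound 4 leaves those as they are in compound 1. Compounds 2 and 3 already carry hydrogen at the saturated ring carbon, and compound 2 still gives 75.7 nM, so a large loss is not expected.

Going by these compounds, no step beyond the scatter is expected, and the direction stays open, with the expected change being a 1.1-fold higher number from compound 1 to compound 4 (0.03 log units; within the scatter). For compound 4 the estimate is 100 nM, with an expected range from 40 nM to 280 nM.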

Compound 4, half-maximal inhibitory concentration: 244 nM
Compound 4: middle estimate off by 2.4-fold (0.39 log units), on the low side; the measured number falls inside the stated range.
By their numbers in this assay, from the lowest: compounds 2 and 1 (each within the scatter of the next); then compounds 4 and 3 (each within the scatter of the next).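

Removing the vinyl group from the saturated ring carbon of the five-membered ring gives a 2.6-fold higher number from compound 1 to compound 4 (0.42 log units; beyond the scatter) in this assay, so this position does influence the number. Within the data shown here, the earlier compounds offered no matched pair at this carbon, and this modest step is the first direct reading: with the aromatic ring of compound 1 kept unchanged, vinyl goes with stronger inhibition than hydrogen. No measurement is available to explain the step, so the data cannot tell whether the double bond or simply the two carbons of the vinyl group matter.

Only vinyl and hydrogen are shown at this carbon, so an ethyl group, which has the same carbon count without the double bond, or a longer chain would be needed to separate those two possibilities. Going by these compounds, whether the step would be the same size with the aromatic substituents of compound 2 or compound 3 also stays open.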